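Amide variation on the hexafluoropropanol-naphthyl core

The source may report more compounds than this note shows. Statements on the series, on what has been measured and on what is new or still open speak of the compounds shown alone.

Measured so far:
- compound 1, `CC(C)CCC(=O)Nc1c(C(O)(C(F)(F)F)C(F)(F)F)ccc2ccccc12`: 49 nM
- compound 2, `O=C(Nc1c(C(O)(C(F)(F)F)C(F)(F)F)ccc2ccccc12)C1CCCC1`: 495 nM
- compound 3, `O=C(CCc1ccccc1)Nc1c(C(O)(C(F)(F)F)C(F)(F)F)ccc2ccccc12`: 1750 nM

All three share one core and differ only in the group on the carbonyl carbon. In an assay on LtK cells with ATP-sensitive inward rectifier potassium channel 11 (Homo sapiens) as the target (a lower number here means that less compound is needed, a higher number that more compound is needed for the effect), compound 1 gives the lowest number and compound 3 the highest: a 36-fold higher number from compound 1 to compound 3 (1.55 log units; beyond the scatter), a 3.5-fold higher number from compound 2 to compound 3 (0.55 log units; beyond the scatter), with a 10-fold higher number from compound 1 to compound 2 (1.00 log units; beyond the scatter) between the two smaller groups. Compound 3 thus stands at the top of the three, well beyond the scatter from either neighbour.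

Compound 4, `O=C(Nc1c(C(O)(C(F)(F)F)C(F)(F)F)ccc2ccccc12)c1ccc(F)cc1`, follows from compound 3 by 4-fluorophenyl in place of phenethyl on a carbonyl carbon; cut one bond further out the change reads phenethylcarbonyl to (4-fluorophenyl)carbonyl. For the measured compounds named here, no measured step puts an aromatic ring directly on the carbonyl carbon, so the bearing steps are indirect. The step from compound 1 to compound 3 shows that bringing in phenyl on the chain raised the number strongly, and the step from compound 2 to compound 3 that the phenethyl group is the least favourable of the three. Removing the chain carbons while keeping an aromatic ring is expected to move the number back down only modestly, if at all, so the estimated step is a 1.5-fold lower number from compound 3 to compound 4 (0.16 log units; within the scatter). Compound 4 is expected to give about 1200 nM in this assay, within 250 nM to 6000 nM.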

Compound 4, half-maximal effective concentration: 70 nM
For compound 4 the middle estimate is 17-fold (1.23 log units) above the measured one; the measured number lies below the stated range.
By their numbers in this assay, from the lowest: compounds 1 and 4 (each within the scatter of the next); then compound 2; then compound 3.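

The result shows that an aromatic ring on the carbonyl carbon is compatible with a low number in this assay: a 25-fold lower number from compound 3 to compound 4 (1.40 log units; beyond the scatter), so the high number of phenethyl does not extend to every aromatic group at this position. 4-Fluorophenyl also compares well with cyclopentyl, with a 7.1-fold lower number from compound 2 to compound 4 (0.85 log units; beyond the scatter), while a 1.4-fold higher number from compound 1 to compound 4 (0.15 log units; within the scatter), which lies within the scatter, so isopentyl and 4-fluorophenyl serve equally well here despite their different shapes. Nothing at hand gives a reason for the gap between the two aromatic groups.

On these data alone, the step from compound 3 to compound 4 changes both the chain and the fluorine, so the share of each remains open; plain phenyl and benzyl on the carbonyl carbon would separate them. Also open, as far as these compounds go, is how a pyridine ring or a longer chain would read in this place.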